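Aryl substituent variation in the tosyl amidine series

The source may hold more compounds than are shown below. What is called first, only, known or untested is meant among the compounds shown, and "the series" means these compounds.

Measured compounds in a functional assay on MCF7 cells (Homo sapiens) for cytotoxicity, read by MTT assay, with a stated time of 48 h; a higher number here means a weaker inhibitor, a lower number a stronger inhibitor:
compound 1, `Cc1ccc(S(=O)(=O)/N=C(/CCNC2=CC(=O)c3ccccc3C2=O)Nc2ccccc2[N+](=O)[O-])cc1`; compound 1 gives 3090 nM
compound 2, `Cc1ccc(S(=O)(=O)/N=C(/CCNC2=CC(=O)c3ccccc3C2=O)Nc2ccccc2I)cc1`; compound 2 gives 15500 nM
compound 3, `Cc1ccc(S(=O)(=O)/N=C(/CCNC2=CC(=O)c3ccccc3C2=O)Nc2cccc(C)c2)cc1`; compound 3 gives 8120 nM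

Compound 3 sits at the upper end of the three numbers. It is separated from compound 1 by a 2.6-fold higher number from compound 1 to compound 3 (0.42 log units; beyond the scatter), while its gap to compound 2, a 1.9-fold lower number from compound 2 to compound 3 (0.28 log units; within the scatter), is within the scatter, so compound 2 and compound 3 cannot be ordered against each other.

Compound 4, `Cc1ccc(S(=O)(=O)/N=C(/CCNC2=CC(=O)c3ccccc3C2=O)Nc2cccc(C(F)(F)F)c2)cc1`, is the next member. The change from compound 3 is trifluoromethyl in place of methyl on an aromatic carbon. The measured steps all alter the substituent on the same aryl ring: a 5.0-fold higher number from compound 1 to compound 2 (0.70 log units; beyond the scatter) exchanges one group for another at a fixed place, and a 2.6-fold higher number from compound 1 to compound 3 (0.42 log units; beyond the scatter) together with a 1.9-fold lower number from compound 2 to compound 3 (0.28 log units; within the scatter) change both the group and its place. Within the data shown here, none of them exchanges methyl for trifluoromethyl, so no direct precedent exists. Given that the whole span of the three numbers is modest, the step of a 1.2-fold lower number from compound 3 to compound 4 (0.06 log units; within the scatter) is expected to stay within the scatter. Compound 4 is therefore estimated at 7000 nM, with a range of 2500 nM to 20000 nM.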

Compound 4, half-maximal inhibitory concentration: 89100 nM
Beside the measured number, compound 4's estimate is 13-fold (1.10 log units) below it; the measured number lies above the stated range.
By their numbers in this assay, from the lowest: compound 1; then compounds 3 and 2 (each within the scatter of the next); then compound 4.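

In this assay, among these compounds, the exchange of methyl for trifluoromethyl at this aromatic carbon gives the first large step among the aryl changes that involve a single group, an 11-fold higher number from compound 3 to compound 4 (1.04 log units; beyond the scatter). Compound 4 is the weakest of the four, with a 5.7-fold higher number from compound 2 to compound 4 (0.76 log units; beyond the scatter) and a 29-fold higher number from compound 1 to compound 4 (1.46 log units; beyond the scatter), so the range of the series is wider than the three earlier numbers suggested. One group on this ring can therefore shift the number far more than the iodo, nitro and methyl variations alone indicated.

A single exchange at this carbon leaves open how a chloro group, a methoxy group or a nitrile would compare with methyl and trifluoromethyl, and whether trifluoromethyl in place of the nitro or iodo group would give a similar number. No measurement at hand speaks to what lies behind the step.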